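This account rests on a few compounds, and the source may have more. Where it says the series, first, only, none or still open, it means among the compounds named here.

Compound 3, `NCCS(=O)(=O)CCOc1ccc([C@H]2CC[C@]3(CC2)OOC2(O3)C3CC4CC(C3)CC2C4)cc1`, is one of three compounds built on the same shared core, and they differ only in the chain attached to the oxygen on the aromatic ring. In an ADME assay on microsomes from liver (Homo sapiens) for metabolic stability, read by LC-MS, tested at 1 uM (on this read-out higher numbers stand for fast clearance and lower numbers for slow clearance), compound 3 gives 9 mL.min-1.g-1, the smallest of the three numbers as written, though not separated from every other compound. Compound 1, `c1cc([C@H]2CC[C@]3(CC2)OOC2(O3)C3CC4CC(C3)CC2C4)ccc1OCCCNC1CCOCC1`, gives 10 mL.min-1.g-1 in this assay, and compound 2, `CS(=O)(=O)N1CCN(CCCOc2ccc([C@H]3CC[C@]4(CC3)OOC3(O4)C4CC5CC(C4)CC3C5)cc2)CC1`, gives 68 mL.min-1.g-1. The gap from compound 1 to compound 3 is a 1.1-fold lower number from compound 1 to compound 3 (0.05 log units; within the scatter), so these two effectively sit together, whereas a 7.6-fold lower number from compound 2 to compound 3 (0.88 log units; beyond the scatter) sets compound 2 clearly apart from compound 3.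

Compound 4, `CC1(C)CC(O)(COc2ccc([C@H]3CC[C@]4(CC3)OOC3(O4)C4CC5CC(C4)CC3C5)cc2)CC(C)(C)N1`, carries yet another end on that chain: 4-hydroxy-2,2,6,6-tetramethylpiperidin-4-yl in place of ((2-aminoethyl)sulfonyl)methyl on a saturated chain carbon bound to an oxygen on an aromatic ring. The two measured steps that alter this same chain are a 1.1-fold lower number from compound 1 to compound 3 (0.05 log units; within the scatter) and a 7.6-fold lower number from compound 2 to compound 3 (0.88 log units; beyond the scatter); one is within the scatter and the other is a modest change. Neither of the groups involved in those steps resembles the 4-hydroxy-2,2,6,6-tetramethylpiperidin-4-yl group entering in compound 4, so the measured steps only bracket the plausible outcome. A small rise, possibly within the scatter, is expected; the estimated step is a 2.0-fold higher number from compound 3 to compound 4 (0.30 log units; within the scatter). The estimate for compound 4 in this assay is 18 mL.min-1.g-1, expected within a range from 6 mL.min-1.g-1 to 55 mL.min-1.g-1.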

Compound 4, intrinsic clearance in microsomes: 14 mL.min-1.g-1
The estimate for compound 4 lay 1.3-fold (0.11 log units) above the measured number; low and high end bracket the measured number.
By their numbers in this assay, from the lowest: compounds 3, 1 and 4 (each within the scatter of the next); then compound 2.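

In this assay, the chain end 4-hydroxy-2,2,6,6-tetramethylpiperidin-4-yl brings no change that can be told from the scatter, with a 1.6-fold higher number from compound 3 to compound 4 (0.19 log units; within the scatter) and a 1.4-fold higher number from compound 1 to compound 4 (0.15 log units; within the scatter) as its two small steps, so compound 4 joins compound 1 and compound 3 as one group. Compound 2 stays apart, with a 4.9-fold lower number from compound 2 to compound 4 (0.69 log units; beyond the scatter) on the far side of the scatter, which shows that the high number of compound 2 does not come with every chain end that carries a six-membered non-aromatic ring: compound 1 and compound 4 both have such a ring and sit with ring-free compound 3, while compound 2 alone goes against that grouping. Nothing presented here bears on the reason for this result.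

These compounds cannot separate the parts of the new end, so a plain piperidin-4-yl group, with neither the hydroxy nor the methyl groups, would test whether the ring alone is enough to stay in the low group. A carboxylic acid at the end of the same chain would also show whether this low group extends to a quite different kind of end.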